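Tolerated concentration on swapping an ethoxycarbonylaminomethyl for pyridin-2-yl

This account rests on a few compounds, and the source may have more. Where it says the series, first, only, none or still open, it means among the compounds named here.

Two compounds of the series have numbers in an ADME assay on cells (Homo sapiens) for cytotoxicity, read by polymerase chain reaction, with a stated time of 3 days; a lower number here means that less compound is tolerated, a higher number that more compound is tolerated. Compound 1 `Nc1nc(Cl)c(-c2nc3ccc(Cl)cc3s2)c(N[C@@H]2C[C@H](CO)[C@@H](O)[C@H]2O)n1` gives 16000 nM. Compound 2 `CCOC(=O)NCCNc1nc(C)c(-c2nc3ccccc3s2)c(N[C@@H]2C[C@H](CO)[C@@H](O)[C@H]2O)n1` gives 12000 nM, the smaller of the two numbers, though the gap to compound 1 lies within the usual scatter and does not separate them. Compound 3 `Cc1nc(NCc2ccccn2)nc(N[C@@H]2C[C@H](CO)[C@@H](O)[C@H]2O)c1-c1nc2ccccc2s1` differs from compound 2 by pyridin-2-yl in place of ((ethoxycarbonyl)amino)methyl on a saturated chain carbon bound to a nitrogen on an aromatic ring. Going by the values given here, no measured pair shows this change, so nothing on record sets its size or direction. Compound 3 is expected to sit near compound 2, with a step of no change at the digits printed from compound 2 to compound 3 (within the scatter) that is not expected to exceed the scatter; the estimate is 12000 nM, between 5000 nM and 30000 nM.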

Compound 3, half-maximal cytotoxic concentration: 13000 nM
Beside the measured number, compound 3's estimate is 1.1-fold (0.03 log units) below it; low and high end bracket the measured number.
By their numbers in this assay, from the lowest: compounds 2, 3 and 1 (each within the scatter of the next).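

The earlier compounds shown here gave no step at this position; now this assay reads a 1.1-fold higher number from compound 2 to compound 3 (0.03 log units; within the scatter) for this change. On a saturated chain carbon bound to a nitrogen on an aromatic ring, pyridin-2-yl and ((ethoxycarbonyl)amino)methyl are therefore not told apart, although one carries a six-membered aromatic ring and the other no ring. Nothing at hand accounts for this.

Still open, as far as these compounds go, is whether a primary amine or a carboxylic acid at this place would also stay within the scatter. From the compounds shown here alone, a longer chain carrying pyridin-2-yl is equally open.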